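Series notes: chloro for hydrogen on the anilino ring

The source may hold more compounds than are shown below. What is called first, only, known or untested is meant among the compounds shown, and "the series" means these compounds.

Of the compounds shown here, three have numbers so far. Compound 1 `O=C(/C=C/c1ccccc1)NNC(=O)c1ccccc1O` gives 39300 nM in a functional assay on HL-60 cells (Homo sapiens) for cytotoxicity, read by MTT assay, with a stated time of 72 h; a higher number here means a weaker inhibitor, a lower number a stronger inhibitor. Compound 2 `COCOc1cc(/C=C/C(=O)OCC(=O)NN2CCOCC2)ccc1OCc1ccccc1` gives 50400 nM in this assay. Compound 3 `COc1ccc(/C=C/C(=O)OCC(=O)Nc2ccccc2)cc1OC` gives 46400 nM in this assay, the second highest of the three numbers; its nearest neighbour is compound 2 and its furthest is compound 1, and both gaps lie within the scatter, so the three compounds cannot be told apart on these data.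

Compound 4 `COc1ccc(/C=C/C(=O)OCC(=O)Nc2ccc(Cl)cc2)cc1OC` has not been measured. It differs from compound 3 by chloro in place of hydrogen on an aromatic carbon, a chloro in place of hydrogen on an aromatic carbon, so that the anilino becomes (4-chlorophenyl)amino. For the measured compounds named here, no measured pair in the set shows this change, so there is no basis in the data for a step beyond the scatter in either direction. The expectation is that the step of a 1.2-fold lower number from compound 3 to compound 4 (0.09 log units; within the scatter) stays within the scatter. Compound 4 is therefore estimated at 38000 nM, with a range from 15000 nM to 95000 nM.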

Compound 4, half-maximal inhibitory concentration: 31900 nM
Beside the measured number, compound 4's estimate is 1.2-fold (0.08 log units) above it, and the stated range covers the measured number.
By their numbers in this assay, from the lowest: compounds 4, 1, 3 and 2 (each within the scatter of the next).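

For the compounds shown here, this is the first measured pair, and it gives chloro in place of hydrogen on an aromatic carbon, para to a large group, a size: in this assay the step reads a 1.5-fold lower number from compound 3 to compound 4 (0.16 log units; within the scatter) and so lies within the scatter. At this position, then, phenyl to 4-chlorophenyl does not separate the two compounds, although this rests on a single pair. Nothing at hand bears on why the step has this size.

From the compounds shown here alone, whether an amine, a methoxy or a nitro group in the same place would also stay within the scatter remains open. Going by these compounds, it is equally open whether the chloro step would read the same with a carboxylic acid on the anilino ring or with a longer chain in place of the anilide.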